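The source may report more compounds than this note shows. Statements on the series, on what has been measured and on what is new or still open speak of the compounds shown alone.

Measured so far:
Compound 1 `CC(=O)CC/C=C(\C)CCC1=C(C)CCCC1(C)C`, tested in a functional assay on U-251 cells (Homo sapiens) for inhibition; a lower number here means a stronger inhibitor of growth, a higher number a weaker inhibitor of growth: compound 1 gives > 15000 nM, which is a limit of the assay rather than a number.
Compound 2 `C=C1CCCC(C)(C)C1CC[C@@]1(C)CC[C@H]([C@@H](C)C(=O)O)OO1`: in this assay compound 2 gives 4330 nM.

Among the measured compounds shown here, compound 2 thus supplies the only actual number here; the other result, that of compound 1, is the limit of > 15000 nM in this assay, at which 1 of the 2 values shown sits. For the measured compounds named here, no step between two measured compounds is available, so nothing measured tells how large a change of the kind below tends to be.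

Compound 3 `C=C1CCCC(C)(C)C1CC[C@]1(C)CC[C@@H]([C@@H](C)C(=O)O)OO1` has the same atoms and bonds as compound 2 and differs only in stereochemistry: the two compounds have the same atoms and bonds; at least one stereo element is drawn with a configuration in one of them and without one in the other: 2 of 4 stereo elements differ; a stereocentre at a saturated ring carbon is drawn S in compound 2 and R in compound 3; a stereocentre at a saturated ring carbon is drawn R in compound 2 and S in compound 3. A change of this kind can shift growth inhibition in either direction, or not at all beyond the usual scatter. Going by the values given here, with no measured pair to lean on, the expectation is a modest weakening with wide uncertainty. The step from compound 2 to compound 3 is expected to be a 1.5-fold higher number from compound 2 to compound 3 (0.18 log units; within the scatter). Compound 3 is therefore expected to give about 6500 nM, within 1500 nM to 20000 nM.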

Compound 3, concentration for 50% growth inhibition: > 10000 nM
Compound 3 was reported as a limit (the forecaster's own chance of this, stated with the estimate: 25%); middle value at least 1.5-fold (0.18 log units) from the limit.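

Inverting the drawn configuration at the two saturated ring carbons, with atoms and bonds unchanged, gives an at least 2.3-fold higher number from compound 2 to compound 3 (0.36 log units; beyond the scatter), the only measured step here. The arrangement in space at these two ring carbons therefore matters for growth inhibition in this assay, and compound 2 carries the stronger of the two arrangements shown. For compound 3 the result is a limit of the assay and not a number, so the full size of the step stays unknown: the limit of > 10000 nM in this assay, at which 1 of the 3 values shown sits.

Still open, as far as these compounds go, is how much each of the two ring carbons contributes alone, as both change together in this step. Also open, from the compounds shown here alone, is whether a methyl ester or a primary amide in place of the carboxylic acid would keep the growth inhibition of compound 2.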